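Vero cytotoxicity of the sulfonate and ester pair

The source may hold more compounds than are shown below. What is called first, only, known or untested is meant among the compounds shown, and "the series" means these compounds.

Compound 1 `CC(C)S(=O)(=O)OC1CCC(CN2CCN(c3cc(=O)c4cc(C(F)(F)F)cc([N+](=O)[O-])c4s3)CC2)CC1` is tested in an ADME assay on Vero cells (Chlorocebus sabaeus) for cytotoxicity, read by MTT assay, with a stated time of 48 h (on this read-out lower numbers stand for stronger inhibition and higher numbers for weaker inhibition), where compound 1 gives > 64 ug/mL, a limit of the assay rather than a number. Compound 2 `COc1cccc(C(=O)OC2CCC(CN3CCN(c4cc(=O)c5cc(C(F)(F)F)cc([N+](=O)[O-])c5s4)CC3)CC2)c1` returns > 64 ug/mL in this assay, again a limit. The step that the two limits leave unreadable from compound 1 to compound 2 is thus unreadable; both values sit at the same ceiling (the limit of > 64 ug/mL in this assay, at which 2 of the 2 values shown sit). Compound 3 `CC(=O)OC1CCC(CN2CCN(c3cc(=O)c4cc(C(F)(F)F)cc([N+](=O)[O-])c4s3)CC2)CC1` is not yet measured; it differs from compound 1 by acetyl in place of isopropylsulfonyl on an oxygen on a saturated carbon. Among the measured compounds shown here, the only measured step is unreadable, and no size for this change can be taken from it. Compound 3 is expected to stay at that ceiling, a step that the limit leaves unreadable from compound 1 to compound 3, with an estimate of 120 ug/mL ranging from 50 ug/mL to 400 ug/mL.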

Compound 3, half-maximal inhibitory concentration: > 64 ug/mL
Compound 3: no number, only a limit; the forecaster's own chance of this, stated with the estimate: 85%; the middle value does not contradict the limit.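

No new step can be read among compound 1, compound 2 and compound 3 in this assay, since each result is a limit and not a number: the limit of > 64 ug/mL in this assay, at which 3 of the 3 values shown sit.

On these data alone, whether the groups on the oxygen differ in cytotoxicity beyond that ceiling remains open.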